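A few compounds are considered here, and "the series" means these few. Any claim that something is new, unique, unknown or untested is made for them only; others in the source may bear on it.

Values measured in an ADME assay on HEK293 cells (Homo sapiens) for cytotoxicity, read by MTT assay, with a stated time of 48 h (on this read-out higher numbers stand for weaker inhibition and lower numbers for stronger inhibition), are:

- compound 1 `CN1CCN(CCCn2c(N)c(-c3nc4ccccc4[nH]3)c3nc(C#N)c(C#N)nc32)CC1` with 6260 nM
- compound 2 `CCCCn1c(N)c(-c2nc3ccccc3[nH]2)c2nc(C#N)c(C#N)nc21` with > 50000 nM

Compound 2 stands at > 50000 nM as a limit of the assay and not a number. Compound 3 `CCN(CC)CCCCn1c(N)c(-c2nc3ccccc3[nH]2)c2nc(C#N)c(C#N)nc21` is built from compound 2 by one change: diethylamino in place of hydrogen on a saturated chain carbon, four bonds along the chain from an aromatic nitrogen so that propyl becomes 3-(diethylamino)propyl. Going by the values given here, the one measured step that bears on this is an at least 7.9-fold higher number from compound 1 to compound 2 (0.90 log units; beyond the scatter) as 4-methylpiperazin-1-yl gives way to methyl. Compound 3 puts an amino group back on the chain, so a step of similar size towards stronger inhibition is expected in this assay here. The estimated move is an at least 7.1-fold lower number from compound 2 to compound 3 (0.85 log units; beyond the scatter) in that direction. For compound 3 the estimate is 7000 nM with 2500 nM to 25000 nM as the expected range.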

Compound 3, half-maximal inhibitory concentration: 5370 nM
Compound 3: middle estimate off by 1.3-fold (0.12 log units), on the high side; the range from low to high includes it.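

In this assay, diethylamino on the chain gives an at least 9.3-fold lower number from compound 2 to compound 3 (0.96 log units; beyond the scatter), so an amino group without a ring goes with the lower number here, as the 4-methylpiperazin-1-yl group of compound 1 did. Exchanging one amino group for the other gives a 1.2-fold lower number from compound 1 to compound 3 (0.07 log units; within the scatter), which is within the scatter, so these two groups cannot be told apart in this assay. Compound 2 carries a limit of the assay and not a number, so the first step gives only a minimum size: the limit of > 50000 nM in this assay, at which 1 of the 3 values shown sits.

The compounds shown leave open whether a hydroxyl group or a carboxylic acid in place of diethylamino would go with a similarly low number. They also leave open how a longer chain would change it.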